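This account rests on a few compounds, and the source may have more. Where it says the series, first, only, none or still open, it means among the compounds named here.

Compound 1, `Cc1cc(NC(=O)Nc2ccc(C(=O)O)cc2)c2ccccc2n1`; compound 2, `Cc1cc(NC(=O)Nc2ccc(Cl)cc2)c2ccccc2n1`; compound 3, `Cc1cc(NC(=O)Nc2ccc(C(C)(C)C)cc2)c2ccccc2n1`; compound 4, `CCc1ccc(NC(=O)Nc2cc(C)nc3ccccc23)cc1`, not yet measured.

In an ADME assay on BJ cells (Homo sapiens) for cytotoxicity, with a stated time of 72 h (a lower number here means that less compound is needed, a higher number that more compound is needed for the effect), compound 1 gives > 25000 nM, which is a limit of the assay and not a number. Compound 2 also gives > 25000 nM, again a limit. Going by the values given here, compound 3 gives 20000 nM and so holds the only number among the three measured values; the two others sit at the limit of > 25000 nM in this assay, at which 2 of the 3 values shown sit.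

Compound 4 differs from compound 3 in one place: ethyl in place of tert-butyl on an aromatic carbon. The measured steps that touch the same position are those in which the tert-butyl entered, an at least 1.2-fold lower number from compound 1 to compound 3 (0.09 log units; that floor lies within the scatter) and an at least 1.2-fold lower number from compound 2 to compound 3 (0.09 log units; that floor lies within the scatter). Both are floors set by a limit, and each floor lies within the usual scatter, so they show no clear effect of the tert-butyl at all. Going from compound 1 to compound 2, a step that the two limits leave unreadable from compound 1 to compound 2, adds nothing readable.

With the tert-butyl now leaving in favour of ethyl, no step beyond the scatter is expected in this assay . The step from compound 3 to compound 4 is therefore estimated at a 1.1-fold higher number from compound 3 to compound 4 (0.04 log units; within the scatter). Compound 4 is expected to give about 22000 nM, within roughly 10000 nM to 50000 nM, with a real chance that only a limit is reported.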

Compound 4, half-maximal effective concentration: > 25000 nM
Compound 4 was reported as a limit; the forecaster's own chance of this, stated with the estimate: 50%; middle value at least 1.1-fold (0.05 log units) from the limit.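

In this assay, ethyl in place of tert-butyl gives an at least 1.2-fold higher number from compound 3 to compound 4 (0.09 log units; that floor lies within the scatter). This is only a floor, so the change shows no clear effect, and a second, smaller carbon-only group at this place on the ring adds no readable difference. The steps linking compound 4 to compound 1 and to compound 2 cannot be read, as each has a limit at both ends, and compound 3 remains the only one of the four with a number, while the other three share one limit: the limit of > 25000 nM in this assay, at which 3 of the 4 values shown sit.

The compounds shown leave open how far compound 1, compound 2 and compound 4 really lie past that limit, and so whether carboxy, chloro and ethyl differ from one another at all. They also leave open whether a longer chain such as hexyl, an amine or a phenyl ring at this place would give a step beyond the scatter in this assay, one large enough to read as a real change in the amount of compound needed.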